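From trifluoromethoxy to (trifluoromethyl)sulfanyl on compound 2

This account rests on a few compounds, and the source may have more. Where it says the series, first, only, none or still open, it means among the compounds named here.

In an ADME assay on HepG2 cells (Homo sapiens) for cytotoxicity, with a stated time of 72 h (a lower number here means that less compound is needed, a higher number that more compound is needed for the effect), compound 1 `CCc1ccc(NC(=O)Nc2cc(C)nc3ccccc23)cc1` gives 17000 nM and compound 2 `Cc1cc(NC(=O)Nc2ccc(OC(F)(F)F)cc2)c2ccccc2n1` gives 15000 nM. These two numbers lie within the scatter of each other, so compound 2 stands level with compound 1. Going by the values given here, the only measured step, a 1.1-fold lower number from compound 1 to compound 2 (0.05 log units; within the scatter), exchanges ethyl for trifluoromethoxy on an aromatic carbon.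

Compound 3 `Cc1cc(NC(=O)Nc2ccc(SC(F)(F)F)cc2)c2ccccc2n1` carries (trifluoromethyl)sulfanyl in place of trifluoromethoxy on an aromatic carbon, para to a large group: (trifluoromethyl)sulfanyl in place of trifluoromethoxy on an aromatic carbon. Among the compounds with values here, no measured step makes this exchange, and a single step at this place is thin evidence. Since that step, a 1.1-fold lower number from compound 1 to compound 2 (0.05 log units; within the scatter), stayed within the scatter, no change beyond the scatter is expected in this assay. The expected step is a 1.2-fold lower number from compound 2 to compound 3 (0.06 log units; within the scatter). For compound 3 the estimated value is 13000 nM, with an expected range from 6000 nM to 27000 nM.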

Compound 3, half-maximal effective concentration: 20000 nM
Beside the measured number, compound 3's estimate is 1.5-fold (0.19 log units) below it; the range from low to high includes it.
By their numbers in this assay, from the lowest: compounds 2, 1 and 3 (each within the scatter of the next).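

In this assay putting (trifluoromethyl)sulfanyl in place of trifluoromethoxy on an aromatic carbon, para to a large group, gives a 1.3-fold higher number from compound 2 to compound 3 (0.12 log units; within the scatter) and putting it in place of ethyl gives a 1.2-fold higher number from compound 1 to compound 3 (0.07 log units; within the scatter) at the same place. Where the earlier compounds offered a single exchange here, three groups can now be set against one another at this position, and ethyl, trifluoromethoxy and (trifluoromethyl)sulfanyl all stand level. No measured property of these compounds is at hand to account for this result.

The compounds shown leave open whether an amine, a carboxylic acid or a longer alkyl chain at this position would give a step beyond the scatter. They also leave open whether these exchanges would stay within the scatter on a different core.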